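Replacing the Side Group of Compound 3

A few compounds are considered here, and "the series" means these few. Any claim that something is new, unique, unknown or untested is made for them only; others in the source may bear on it.

Measured in an ADME assay on microsomes from liver (Rattus norvegicus) for metabolic stability, using NADPH, with a stated time of 10 min; a lower number here means that less of the compound is left, a higher number that more of the compound is left:
- Compound 1 `CN(C[C@H]1Cc2c(cccc2N2CCC(N)CC2)CN1)[C@H]1CCCc2cccnc21`: 38.4%
- Compound 2 `CN(C[C@H]1Cc2c(cccc2N2C[C@H]3CNC[C@H]3C2)CN1)[C@H]1CCCc2cccnc21`: 38.1%
- Compound 3 `CN(C)C1CCN(c2cccc3c2C[C@H](CN(C)[C@H]2CCCc4cccnc42)NC3)CC1`: 52.4%

Compound 3, at 52.4%, stands highest of the three, beyond the scatter from both others. Compound 4 `CN(C[C@H]1Cc2c(cccc2N[C@H]2CC[C@H](N)CC2)CN1)[C@H]1CCCc2cccnc21` has (4-aminocyclohexyl)amino in place of 4-(dimethylamino)piperidin-1-yl on an aromatic carbon. Within the data shown here, no measured compound carries this new group. The closest guide is the exchange of amino for dimethylamino, which gave a number 14 percentage points higher from compound 1 to compound 3 (beyond the scatter). Compound 4 ends in amino again, so a fall of similar size is expected. Changing the ring group while keeping a free ring nitrogen or amino gave only a number 0.3 percentage points lower from compound 1 to compound 2 (within the scatter), and the return to dimethylamino gave a number 14.3 percentage points higher from compound 2 to compound 3 (beyond the scatter). The expected step is a number 12.4 percentage points lower from compound 3 to compound 4 (beyond the scatter). For compound 4 the estimate is 40%, with an expected range from 24% to 58%.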

Compound 4, percent of the compound remaining: 75%
The estimate for compound 4 lay 35 percentage points below the measured number; measured number above the stated range.
By their numbers in this assay, from the lowest: compounds 2 and 1 (each within the scatter of the next); then compound 3; then compound 4.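

In this assay, a free amino group at the end of the side group does not by itself hold the number down: with that amino kept, (4-aminocyclohexyl)amino in place of 4-aminopiperidin-1-yl gives a number 36.6 percentage points higher from compound 1 to compound 4 (beyond the scatter). The same group also gives a number 36.9 percentage points higher from compound 2 to compound 4 (beyond the scatter) and a number 22.6 percentage points higher from compound 3 to compound 4 (beyond the scatter), so at this aromatic carbon, exchanging the ring and its link to the core counts for more than dimethylamino against amino did. No evidence on the reason for this rise is at hand. As far as these compounds go, whether the rise depends on the amino, or would hold with a hydroxyl or a carboxylic acid on the cyclohexyl ring, remains open.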